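A Second Chloro on the Core of Compound 2

The source may report more compounds than this note shows. Statements on the series, on what has been measured and on what is new or still open speak of the compounds shown alone.

Measured compounds:
compound 1 `ClCc1cccc(Cn2cnc3ncnc(Cl)c32)c1` — 1940 nM
compound 2 `ClCc1ccccc1Cn1cnc2ncnc(Cl)c21` — 5880 nM

Both compounds were tested in a functional assay on UACC-257 cells (Homo sapiens) for cytotoxicity, read by sulforhodamine B assay, with a stated time of 48 h; on this read-out higher numbers stand for weaker inhibition of growth and lower numbers for stronger inhibition of growth. Of the two numbers, compound 2 holds the higher one, and the gap to compound 1 lies beyond the usual scatter, so compound 2 is the weaker inhibitor of growth of the pair. Within the data shown here, the two differ only in where the chloromethyl arm sits on the benzyl ring; no step between them has been worked out here, so their values are simply reported side by side.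

Compound 3 `ClCc1ccccc1Cn1cnc2nc(Cl)nc(Cl)c21` has not yet been measured. It differs from compound 2 in one place: chloro in place of hydrogen on an aromatic carbon. Among the measured compounds shown here, nothing among the measured compounds tells how a change at this position of the shared core affects growth inhibition, so the expectation rests on the change being small. In this assay the step from compound 2 is expected to be modest and, if anything, toward stronger inhibition: a 1.5-fold lower number from compound 2 to compound 3 (0.17 log units; within the scatter). Compound 3 is therefore estimated at 4000 nM, with a range from 1500 nM to 12000 nM.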

Compound 3, concentration for 50% growth inhibition: 1990 nM
Estimate against measurement, compound 3: 2.0-fold (0.30 log units) above; measured number inside the range.
By their numbers in this assay, from the lowest: compounds 1 and 3 (each within the scatter of the next); then compound 2.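

Placing a chloro group on the aromatic carbon between two ring nitrogen atoms gives, in this assay, a 3.0-fold lower number from compound 2 to compound 3 (0.47 log units; beyond the scatter), a step that lies beyond the scatter. Among these compounds, compounds 1 and 2 both carry hydrogen at this carbon and differ only in where the chloromethyl arm sits on the benzyl ring, so this is the first sign that a change on the shared core itself can shift the read-out. Here the added chlorine atom is tolerated and goes with stronger inhibition of growth, but nothing available explains why this happens.

A single substituent at this carbon cannot show whether the shift is particular to chloro, and an amine, a methoxy group or a fluoro group in the same place would each test that question. The compounds shown also leave open whether the same exchange of hydrogen for chloro would produce a similar step on compound 1, where the chloromethyl arm occupies a different place on the benzyl ring.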